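The source may report more compounds than this note shows. Statements on the series, on what has been measured and on what is new or still open speak of the compounds shown alone.

Measured compounds:
compound 1 `O=C1O[C@H]([C@@H](O)Cn2cc(-c3cccc(O)c3)nn2)C(OCc2ccccc2)=C1OCc1ccccc1` with > 100000 nM
compound 2 `O=C1O[C@H]([C@@H](O)Cn2cc(CNS(=O)(=O)c3ccc(Cl)cc3)nn2)C(OCc2ccccc2)=C1OCc1ccccc1` with 18000 nM
compound 3 `Cc1ccc(-c2cn(C[C@H](O)[C@H]3OC(=O)C(OCc4ccccc4)=C3OCc3ccccc3)nn2)cc1` with > 100000 nM

In a functional assay on SW-620 cells (Homo sapiens) for antiproliferative activity, read by MTT assay, with a stated time of 72 h (on this read-out higher numbers stand for weaker inhibition and lower numbers for stronger inhibition), compound 3 gives only a limit, > 100000 nM; it is the limit of this assay and no number. Compound 1 also sits at that limit, > 100000 nM. Compound 2 carries a number, 18000 nM, and the step of an at least 5.5-fold higher number from compound 2 to compound 3 (0.74 log units; beyond the scatter) is read against the limit (the limit of > 100000 nM in this assay, at which 2 of the 3 values shown sit). The step that the two limits leave unreadable from compound 1 to compound 3 cannot be read.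

Compound 4 `O=C1O[C@H]([C@@H](O)Cn2cc(-c3cc(F)cc(F)c3)nn2)C(OCc2ccccc2)=C1OCc1ccccc1` differs from compound 3 by 3,5-difluorophenyl in place of 4-methylphenyl on an aromatic carbon. Both aryl-bearing compounds, compound 1 and compound 3, stand at the limit, so no step beyond the scatter is expected; compound 4 is expected to remain at the limit, a step that the limit leaves unreadable from compound 3 to compound 4. The estimate for compound 4 is 150000 nM, between 40000 nM and 600000 nM.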

Compound 4, half-maximal inhibitory concentration: > 100000 nM
Compound 4: no number, only a limit (the forecaster's own chance of this, stated with the estimate: 75%); the middle value is on the limit's open side.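

In this assay compound 4 gives > 100000 nM, which is a limit and not a number. A third directly attached aryl group, 3,5-difluorophenyl, therefore joins 3-hydroxyphenyl and 4-methylphenyl at the limit, and the (((4-chlorophenyl)sulfonyl)amino)methyl group remains the only one shown with a number, with an at least 5.5-fold higher number from compound 2 to compound 4 (0.74 log units; beyond the scatter). The steps among compound 1, compound 3 and compound 4 cannot be read: the limit of > 100000 nM in this assay, at which 3 of the 4 values shown sit.

Any real differences among these three aryl compounds remain hidden beyond the limit. Going by these compounds, an aminomethyl group or a longer alkyl chain on this aromatic carbon remains open.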